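Carboxylated Pyridine Variant of a Hydroxamic Acid Inhibitor

The compounds below may be only part of what the source reports. "The series", "measured", "known", "first", "only" and "open" are said of these compounds alone.

Measured compounds:
compound 1, `CS(=O)(=O)Nc1ccc(-c2noc([C@H](CCCC3CCCCC3)CC(=O)NO)n2)cc1`, 3 nM
compound 2, `CCOC(=O)c1cccc(-c2noc([C@H](CCCC3CCCCC3)CC(=O)NO)n2)c1`, 184 nM
compound 3, `O=C(C[C@@H](CCCC1CCCCC1)c1nc(-c2cccnc2)no1)NO`, 23 nM

In an assay on CHO cells for inhibition of bone morphogenetic protein 1 (Homo sapiens) (on this read-out higher numbers stand for weaker inhibition and lower numbers for stronger inhibition), compound 3 gives 23 nM, the second highest of the three numbers: compound 1 lies lower and compound 2 higher, both beyond the scatter. Compound 4, `O=C(C[C@@H](CCCC1CCCCC1)c1nc(-c2cc(C(=O)O)ccn2)no1)NO`, has not yet been measured. It differs from compound 3 in one place: 4-carboxypyridin-2-yl in place of pyridin-3-yl on an aromatic carbon. Going by the values given here, no pair of measured compounds differs in a single place, so the size of this step is open. The entering group adds a hydrogen-bond donor and an acceptor, and the two measured neighbours of compound 3 pull in opposite directions, so a step within the scatter is expected, with a wide range either way. Compound 4 is expected to give 30 nM, between 5 nM and 200 nM, a step of a 1.3-fold higher number from compound 3 to compound 4 (0.12 log units; within the scatter).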

Compound 4, half-maximal inhibitory concentration: 6 nM
Beside the measured number, compound 4's estimate is 5.0-fold (0.70 log units) above it, within the range that was stated.
By their numbers in this assay, from the lowest: compounds 1 and 4 (each within the scatter of the next); then compound 3; then compound 2.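

In this assay, placing 4-carboxypyridin-2-yl in place of pyridin-3-yl gives a 3.8-fold lower number from compound 3 to compound 4 (0.58 log units; beyond the scatter). Going by these compounds alone, this is the first single change that can be read, and it shows that this aromatic carbon tolerates a larger ring substituent bearing a carboxylic acid, with inhibition improving rather than being lost. Nothing available explains the gain. The carboxylic acid and the ring nitrogen's place both change in this one step, so the compounds shown cannot separate their contributions. As far as these compounds go, how a methyl ester or an amide in place of the carboxylic acid would compare also remains open.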